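The source may report more compounds than this note shows. Statements on the series, on what has been measured and on what is new or still open speak of the compounds shown alone.

In a functional assay on CCRF-CEM cells (Homo sapiens) for cytotoxicity (a lower number here means that less compound is tolerated, a higher number that more compound is tolerated), compound 1 (`CCCCCCCCCCCC(=O)Nc1nc(N)nc2c1ncn2[C@H]1CO[C@@H](CO)O1`) gives 13000 nM. Compound 2 (`CCCCCCCCCCCCCCCC(=O)Nc1nc(N)nc2c1ncn2[C@H]1CO[C@@H](CO)O1`) stands at > 100000 nM, which is a limit and not a number. Compound 3 (`CCCCCCCC/C=C\CCCCCCCC(=O)Nc1nc(N)nc2c1ncn2[C@H]1CO[C@@H](CO)O1`) differs from compound 2 by dec-1-en-1-yl in place of octyl on a saturated chain carbon, seven bonds along the chain from a carbonyl carbon, with dec-1-en-1-yl in place of octyl on a saturated chain carbon, seven bonds along the chain from a carbonyl carbon. Among the compounds with values here, only one measured step bears on this: an at least 7.6-fold higher number from compound 1 to compound 2 (0.88 log units; beyond the scatter), which is beyond the scatter and also ends at the limit. Within the data shown here, with that step as the sole guide, a number staying high in this assay is expected, with no clear step in either direction. The expected step is an at least 1.4-fold lower number from compound 2 to compound 3 (0.15 log units; that floor lies within the scatter). Compound 3 is estimated at 70000 nM, within a range of 20000 nM to 150000 nM.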

Compound 3, half-maximal cytotoxic concentration: 13000 nM
Estimate against measurement, compound 3: 5.4-fold (0.73 log units) above; the measured number lies below the stated range.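

In this assay, the saturated chain carbon seven bonds along the chain from a carbonyl carbon responds to dec-1-en-1-yl in place of octyl, giving an at least 7.6-fold lower number from compound 2 to compound 3 (0.88 log units; beyond the scatter). Chain length alone does not order these compounds: the rise from the shorter chain of compound 1 to compound 2 is not carried on by the still longer chain of compound 3, which shows no change at the digits printed from compound 1 to compound 3 (within the scatter). Compound 2 gives a limit and not a number: the limit of > 100000 nM in this assay, at which 1 of the 3 values shown sits.

As far as these compounds go, the double bond and the two added carbons change together here, so their shares in this step remain open. Decyl in place of octyl at this place, with no double bond, would separate the two.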